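Working notes: 4-fluorophenyl in place of 3-methoxyphenyl

A few compounds are considered here, and "the series" means these few. Any claim that something is new, unique, unknown or untested is made for them only; others in the source may bear on it.

Measured so far in a functional assay on HCT-116 cells (Homo sapiens), read by fluorescence and BrdU incorporation, with a stated time of 48 h, tested at 10 uM; on this read-out lower numbers stand for a stronger effect and higher numbers for a weaker effect at the one concentration tested:
compound 1 `COc1cccc(/C=C/C(=O)c2c(OC)cc(OC)cc2OC)c1` gives 20%
compound 2 `COc1cc(O)c(C(=O)/C=C/c2ccccc2SC)c(OC)c1` gives 52%

Compound 1 stands lowest of the two numbers; compound 2 lies higher, beyond the scatter. Compound 3 `COc1cc(OC)c(C(=O)/C=C/c2ccc(F)cc2)c(OC)c1` differs from compound 1 in one place: 4-fluorophenyl in place of 3-methoxyphenyl on a double-bonded chain carbon bound to a double-bonded chain carbon. For the measured compounds named here, no step between measured compounds covers this change, so the expectation rests on compound 1 at 20% alone. A modest shift toward a higher number, near the edge of the scatter, is expected, a number 10 percentage points higher from compound 1 to compound 3 (within the scatter). Compound 3 is estimated at 30%, within 10% to 55%.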

Compound 3, a percentage reported as activity, at one concentration (the size of the read-out at that concentration, not a potency): 23%
Compound 3: middle estimate off by 7 percentage points, on the high side; measured number inside the range.
By their numbers in this assay, from the lowest: compounds 1 and 3 (each within the scatter of the next); then compound 2.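

In this assay 4-fluorophenyl in place of 3-methoxyphenyl on a double-bonded chain carbon bound to a double-bonded chain carbon gives a number 3 percentage points higher from compound 1 to compound 3 (within the scatter), so the two groups cannot be told apart at this place. The read-out therefore holds with a fluorine in place of the methoxy group's oxygen and its one hydrogen-bond acceptor, at least for this pair. Nothing available explains this result.

Open, going by these compounds, is whether an amine or a carboxylic acid on this phenyl ring would hold the read-out at this level. Equally open, on these data alone, is whether a longer chain in place of the ring would do so.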